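From compound 1 to compound 4: an expected step

The source may report more compounds than this note shows. Statements on the series, on what has been measured and on what is new or still open speak of the compounds shown alone.

Compound 1 `CC1=CC[C@@H]([C@@](C)(O)CCCC(C)(C)NC(=S)NN)CC1` gives the lowest of the two numbers in a functional assay on NCI/ADR cells (Homo sapiens) for cytotoxicity, read by sulforhodamine B assay (a higher number here means a weaker inhibitor of growth, a lower number a stronger inhibitor of growth), with 29000 nM. Compound 2 `CC1=CC[C@@H]([C@@](C)(O)CCCC(C)(C)NC(=S)N/N=C\c2cccc([N+](=O)[O-])c2)CC1` stands close to it in this assay with 38000 nM, inside the scatter. Compound 3 `CC1=CC[C@@H]([C@@](C)(O)CCCC(C)(C)NC(=S)N/N=C\c2ccc([N+](=O)[O-])cc2)CC1` reaches only a limit of this assay, > 100000 nM. Among the measured compounds shown here, the single measured step, an at least 2.6-fold higher number from compound 2 to compound 3 (0.42 log units; beyond the scatter), is bounded by the limit of > 100000 nM in this assay, at which 1 of the 3 values shown sits. Compound 4 `CC1=CC[C@@H]([C@@](C)(O)CCCC(C)(C)NC(=S)N/N=C\c2cccc(Cl)c2)CC1` differs from compound 1 by a group of 9 heavy atoms (7 carbon, 1 nitrogen, 1 chlorine; one six-membered aromatic ring of carbon only) in place of one nitrogen atom, on an amide-type nitrogen. For the measured compounds named here, no measured step covers this change directly; compounds 1 and 2 show that a comparable replacement left the two values within the scatter of each other. The expected step is therefore a 1.2-fold higher number from compound 1 to compound 4 (0.08 log units; within the scatter), not beyond the scatter. Compound 4 is estimated at 35000 nM, with a range from 15000 nM to 90000 nM.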

Compound 4, concentration for total growth inhibition: 31900 nM
Compound 4: the middle estimate sits 1.1-fold (0.04 log units) above what was measured; the measured number falls inside the stated range.
By their numbers in this assay, from the lowest: compounds 1, 4 and 2 (each within the scatter of the next). At a limit, above all of these: compound 3.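

Putting the chlorine-bearing aromatic group on the amide-type nitrogen in place of amino leaves this assay within the scatter, with a 1.1-fold higher number from compound 1 to compound 4 (0.04 log units; within the scatter). Chloro in place of nitro on an aromatic carbon also stays within the scatter, with a 1.2-fold lower number from compound 2 to compound 4 (0.08 log units; within the scatter). The one step beyond the scatter, 3-chlorophenyl in place of 4-nitrophenyl, is an at least 3.1-fold lower number from compound 3 to compound 4 (0.49 log units; beyond the scatter), and it rests on a limit of the assay: the limit of > 100000 nM in this assay, at which 1 of the 4 values shown sits.

The compounds shown leave open whether that gap follows the nitro group or its place on the ring. On these data alone, a 4-chlorophenyl group would separate the two, and a carboxylic acid on the ring remains untested here.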